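The source may report more compounds than this note shows. Statements on the series, on what has been measured and on what is new or still open speak of the compounds shown alone.

The measured compounds in a functional assay on DU-145 cells (Homo sapiens) for inhibition, read by trypan blue exclusion, with a stated time of 96 h; on this read-out higher numbers stand for weaker inhibition of growth and lower numbers for stronger inhibition of growth:

Compound 1 `Cc1ccsc1/C=C(/SCc1ccc(Cl)cc1)C(=O)c1ccc(Cl)cc1` gives 50000 nM.
Compound 2 `Cc1ccsc1/C=C(/SCc1ccc(Cl)cc1Cl)C(=O)c1ccc(Cl)cc1` gives 10000 nM.
Compound 3 `Cc1ccsc1/C=C(/SCc1ccccc1F)C(=O)c1ccc(Cl)cc1` gives 50000 nM.

Compound 2 stands lowest of the three numbers, with a 5.0-fold lower number from compound 1 to compound 2 (0.70 log units; beyond the scatter) and a 5.0-fold higher number from compound 2 to compound 3 (0.70 log units; beyond the scatter) setting it apart from both neighbours, while compound 1 and compound 3 sit within the scatter of each other, as no change at the digits printed from compound 1 to compound 3 (within the scatter) shows. All three measured steps concern only the group on the saturated chain carbon bound to a sulfur.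

Compound 4 `O=C(/C(=C\c1c(O)cc(O)cc1O)SCc1ccc(Cl)cc1Cl)c1ccc(Cl)cc1` changes a different part of the shared core: 2,4,6-trihydroxyphenyl in place of 3-methylthiophen-2-yl on a double-bonded chain carbon bound to a double-bonded chain carbon. Among the measured compounds shown here, no measured step touches this position, so the measured steps offer no direct guide to its size or direction in this assay. With the benzylthio group of compound 2 kept, the number for compound 4 is expected to remain in the region of compound 2, and the step of no change at the digits printed from compound 2 to compound 4 (within the scatter) is estimated to be no larger than the scatter, though with wide uncertainty. Compound 4 is therefore estimated at 10000 nM, within a range of 2000 nM to 50000 nM.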

Compound 4, concentration for 50% growth inhibition: 25000 nM
Compound 4: the middle estimate sits 2.5-fold (0.40 log units) below what was measured, within the range that was stated.
By their numbers in this assay, from the lowest: compound 2; then compounds 4, 1 and 3 (each within the scatter of the next).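

In this assay, among the compounds shown here, the step of a 2.5-fold higher number from compound 2 to compound 4 (0.40 log units; beyond the scatter) shows that the group on a double-bonded chain carbon bound to a double-bonded chain carbon also influences the number, whereas the earlier steps covered only the group on the saturated chain carbon bound to a sulfur. The exchange of 3-methylthiophen-2-yl for 2,4,6-trihydroxyphenyl, which brings 3 hydrogen-bond donors where there were 0, gives weaker inhibition of growth, though the step is modest. No supporting evidence is available to explain this shift.

This single step cannot separate the effect of replacing the ring from that of adding the hydroxy groups, and a plain phenyl group at this place would help to tell them apart. On these data alone, how an amine or a carboxylic acid on the ring would compare also remains open.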